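Sulfonyl aryl exchange on a shared core: compound 4

The source may hold more compounds than are shown below. What is called first, only, known or untested is meant among the compounds shown, and "the series" means these compounds.

Among the measured compounds shown here, compound 1 `CNCc1cn(S(=O)(=O)c2ccco2)c(-c2cccnc2F)c1F` stands lowest of the three numbers measured so far in a physicochemical assay for lipophilicity, read by HPLC, at pH 7.4; a lower number here means a more polar compound, a higher number a more lipophilic compound: compound 1 gives 0.2, while compound 2 `CNCc1cn(S(=O)(=O)c2ncccc2C)c(-c2cccnc2F)c1F` gives 0.32 and compound 3 `CNCc1cn(S(=O)(=O)c2ccc(F)cn2)c(-c2cccnc2F)c1F` gives 0.42, both within the scatter of compound 1. Compound 4 `CNCc1cn(S(=O)(=O)c2cccnc2Cl)c(-c2cccnc2F)c1F` differs from compound 1 as follows: 2-chloropyridin-3-yl in place of furan-2-yl on a sulfonyl sulfur. For the measured compounds named here, the steps that bear on this change are a number 0.12 log units higher from compound 1 to compound 2 (within the scatter) and a number 0.22 log units higher from compound 1 to compound 3 (within the scatter), both small, with a number 0.10 log units higher from compound 2 to compound 3 (within the scatter) between the two pyridyl analogues. A six-membered ring carrying chlorine in place of the furan-2-yl is expected to move the number upward somewhat more than either measured step, giving an expected a number 0.40 log units higher from compound 1 to compound 4 (beyond the scatter). Compound 4 is therefore estimated at 0.6, in a range from 0.3 to 0.9.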

Compound 4, distribution coefficient: 0.75
For compound 4 the middle estimate is 0.15 log units below the measured one, and the stated range covers the measured number.
By their numbers in this assay, from the lowest: compounds 1, 2 and 3 (each within the scatter of the next); then compound 4.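

In this assay the position on a sulfonyl sulfur now gives steps beyond the scatter: a number 0.55 log units higher from compound 1 to compound 4 (beyond the scatter) and a number 0.43 log units higher from compound 2 to compound 4 (beyond the scatter) and a number 0.33 log units higher from compound 3 to compound 4 (beyond the scatter). Compound 1, compound 2 and compound 3 stay within the scatter of one another, so 2-chloropyridin-3-yl is the only group shown that separates from the other three. No data shown account for this separation. The compounds shown leave open whether the chlorine or the pyridin-3-yl ring carries the step, and how a ring bearing an amine or a carboxylic acid would read in this assay.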